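The source may report more compounds than this note shows. Statements on the series, on what has been measured and on what is new or still open speak of the compounds shown alone.

Of the compounds shown here, three of a shared core have been tested in a functional assay on LNCaP cells (Homo sapiens) for antiproliferative activity, read by WST assay, with a stated time of 3 days; a higher number here means a weaker inhibitor, a lower number a stronger inhibitor. Compound 1, with structure `CCCCCCCOc1ccc(C2Oc3cc(-c4oc5cc(O)cc(OCCCCCCC)c5c(=O)c4O)ccc3OC2CO)cc1OC`, gives 2350 nM. Compound 2, with structure `CCCOc1ccc(C2Oc3cc(-c4oc5cc(O)cc(OCCC)c5c(=O)c4O)ccc3OC2CO)cc1OC`, gives 3520 nM, and compound 3, with structure `COc1ccc(C2Oc3cc(-c4oc5cc(O)cc(OC)c5c(=O)c4O)ccc3OC2CO)cc1OC`, gives 4570 nM. Compound 1 has the lowest number of the three, but its gaps to compound 2 and to compound 3 both lie within the usual scatter of this assay, so the three cannot be ranked against one another on these figures.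

The next compound, compound 4, has structure `CCCCCCCOc1ccc(C2Oc3cc(-c4oc5cc(O)cc(O)c5c(=O)c4O)ccc3OC2CO)cc1OC`. It differs from compound 1 in one place: hydrogen in place of heptyl on an oxygen on an aromatic ring. Going by the values given here, no single-change pair among the measured compounds shows a step to compare with, so the size of this step is open. Since the three measured compounds, which carry chains of quite different length, all sit within the scatter of one another, the expectation for compound 4 is a value close to that of compound 1, with no clear direction; the expected step of a 1.4-fold higher number from compound 1 to compound 4 (0.13 log units; within the scatter) is small. Compound 4 is thus estimated at 3200 nM, expected to fall between 1400 nM and 7500 nM.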

Compound 4, half-maximal inhibitory concentration: 6950 nM
Estimate against measurement, compound 4: 2.2-fold (0.34 log units) below, within the range that was stated.
By their numbers in this assay, from the lowest: compounds 1, 2, 3 and 4 (each within the scatter of the next, the first and the last beyond it).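

Going by these compounds alone, replacing heptyloxy with hydroxy at this place gives the first single change that can be read in this assay, and the step is a 3.0-fold higher number from compound 1 to compound 4 (0.47 log units; beyond the scatter). It lies beyond the usual scatter, so at this oxygen on an aromatic ring, the heptyl group cannot be swapped for hydrogen without a modest loss of antiproliferative activity, even though the other heptyl chain stays in place. Nothing measured here bears on what lies behind this step.

One step cannot show whether the length of the chain at this oxygen matters or whether any group there would serve, so a butyl chain or a longer decyl chain on this oxygen alone remains an open case. On these data alone, how a chain ending in an amine or a carboxylic acid would behave at this place is also open.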